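This account rests on a few compounds, and the source may have more. Where it says the series, first, only, none or still open, it means among the compounds named here.

In a functional assay on MCF7 cells (Homo sapiens) for antiproliferative activity, read by sulforhodamine B assay, with a stated time of 72 h (a lower number here means a stronger inhibitor, a higher number a weaker inhibitor), the measured set is short:

compound 1 `FC(F)(F)c1ccc(/C=C\c2cc3ccccc3nc2Cl)cc1` gives 4260 nM
compound 2 `FC(F)(F)c1cccc(/C=C\c2cc3ccccc3nc2Cl)c1` gives 3530 nM
compound 3 `FC(F)(F)c1cc(/C=C\c2cc3ccccc3nc2Cl)cc(C(F)(F)F)c1` gives 7460 nM

Compound 1 and compound 2 are built from the same atoms joined differently; the difference between the two cores is not broken down here, and their two values fall within the scatter of each other. Compound 3 differs from compound 2 by trifluoromethyl in place of hydrogen on an aromatic carbon, and that change produced a 2.1-fold higher number from compound 2 to compound 3 (0.32 log units; beyond the scatter). Compound 4 `FC(F)(F)c1ccc(/C=C\c2cc3ccccc3nc2Cl)c(C(F)(F)F)c1` has not been measured; it differs from compound 1 by trifluoromethyl in place of hydrogen on an aromatic carbon. The place is not identical, since in compound 4 the entering group is ortho to a large group while in compound 3 it is meta to a large group, so the change is the same kind of change, not the same. Because the change gave a 2.1-fold higher number from compound 2 to compound 3 (0.32 log units; beyond the scatter), the expectation is a step of a 2.0-fold higher number from compound 1 to compound 4 (0.30 log units; within the scatter). Compound 4 is estimated at 8500 nM, between 4000 nM and 18000 nM.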

Compound 4, half-maximal inhibitory concentration: 10500 nM
For compound 4 the middle estimate is 1.2-fold (0.09 log units) below the measured one, within the range that was stated.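

In this assay, trifluoromethyl in place of hydrogen on an aromatic carbon gave a 2.5-fold higher number from compound 1 to compound 4 (0.39 log units; beyond the scatter) and this agrees with the earlier step on the other core: the same change on two cores in this assay, a 2.1-fold higher number (0.32 log units; beyond the scatter) from compound 2 to compound 3 and a 2.5-fold higher number (0.39 log units; beyond the scatter) from compound 1 to compound 4, 1.2-fold (0.07 log units) apart, within the scatter of two such steps. The change therefore carried over between these two cores in direction and in size, even with the entering group in compound 4 ortho to a large group. This rests on two pairs only, and it shows neither why the number rises nor that the step would hold on any further core.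

All the compounds shown carry trifluoromethyl as their only substituent on this ring. From the compounds shown here alone, how an amine, a carboxylic acid or a longer chain would behave there remains open.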